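The source may report more compounds than this note shows. Statements on the series, on what has been measured and on what is new or still open speak of the compounds shown alone.

Measured so far in a functional assay on SGC-7901 cells (Homo sapiens) for antiproliferative activity, read by MTT assay, with a stated time of 48 h; a higher number here means that more compound is needed for the effect, a lower number that less compound is needed:

compound 1 `COc1ccc(C(=O)N2N=C(C)CC2c2ccccc2O)cc1` gives 45700 nM
compound 2 `CC1=NN(C(=O)CCl)C(c2cc(F)ccc2O)C1` gives 7000 nM
compound 3 `CC1=NN(S(=O)(=O)c2ccc([N+](=O)[O-])cc2)C(c2cc(Br)ccc2O)C1` gives 27300 nM

Compound 3 at 27300 nM lies within the usual scatter of compound 1, so repeated measurements could not reliably tell these two apart. Compound 2 at 7000 nM needs clearly less compound than compound 3 does, and that gap is beyond the scatter.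

Compound 4 `CC1=NN(S(=O)(=O)c2ccc(C(F)(F)F)cc2)C(c2cc(Br)ccc2O)C1` has not yet been measured. It matches compound 3 except for one group, with trifluoromethyl in place of nitro on an aromatic carbon, para to a large group (trifluoromethyl in place of nitro on an aromatic carbon). Within the data shown here, no two measured compounds differ in only one place, so the data show neither the size nor the direction of the effect of this swap. The expectation in this assay is therefore for no step beyond the scatter, and the best available starting point is compound 3 at 27300 nM for lack of any closer evidence. The estimated change is a 1.2-fold lower number from compound 3 to compound 4 (0.09 log units; within the scatter) and would stay within the scatter. Compound 4 is estimated at 22000 nM (expected range 9000 nM to 55000 nM).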

Compound 4, half-maximal effective concentration: 16300 nM
For compound 4 the middle estimate is 1.3-fold (0.13 log units) above the measured one, within the range that was stated.
By their numbers in this assay, from the lowest: compound 2; then compounds 4, 3 and 1 (each within the scatter of the next, the first and the last beyond it).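

In this assay, replacing nitro with trifluoromethyl on an aromatic carbon, para to a large group, gives the first direct reading of a single change among these compounds: a 1.7-fold lower number from compound 3 to compound 4 (0.22 log units; within the scatter). This step lies within the scatter, so repeated measurements could not reliably separate the two compounds, even though nitro carries hydrogen-bond acceptors and trifluoromethyl carries none. At this position, then, the swap leaves the read-out without a step beyond the scatter, and nothing available here speaks to why the two compounds read alike.

The compounds shown leave open whether any other group at this position, such as an amine, a carboxylic acid or a longer chain, would give a step beyond the scatter, since one swap between two groups cannot show how much the position matters overall. They also leave open whether nitro and trifluoromethyl would still read alike if another part of the shared core were changed, for example with fluoro in place of bromo.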